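Swapping Hydroxymethyl for Ethoxy on the Side Chain

A few compounds are considered here, and "the series" means these few. Any claim that something is new, unique, unknown or untested is made for them only; others in the source may bear on it.

In a functional assay (trachea) with Cavia porcellus as the target (a lower number here means that less compound is needed, a higher number that more compound is needed for the effect), compound 1 (`CCCn1c(=O)n(C)c(=O)c2c1ncn2CCC(=O)O`) gives > 100000 nM as a limit of the assay and not a number. Compound 3 (`CCCn1c(=O)n(C)c(=O)c2c1ncn2CCCO`) gives 22600 nM and lies within the scatter of compound 2 (`CCCn1c(=O)n(C)c(=O)c2c1ncn2CCC#N`) at 27600 nM here. Compound 4 (`CCCn1c(=O)n(C)c(=O)c2c1ncn2CCOCC`) carries ethoxy in place of hydroxymethyl on a saturated chain carbon, two bonds along the chain from an aromatic nitrogen. The closest guide is a 1.2-fold lower number from compound 2 to compound 3 (0.09 log units; within the scatter) and it stays within the scatter. Both an at least 3.6-fold lower number from compound 1 to compound 2 (0.55 log units; beyond the scatter) and an at least 4.4-fold lower number from compound 1 to compound 3 (0.64 log units; beyond the scatter) start from the carboxy limit. For the measured compounds named here, no measured compound carries ethoxy. No step beyond the scatter is therefore expected in this assay in either direction. The expected step is a 1.1-fold lower number from compound 3 to compound 4 (0.05 log units; within the scatter) and remains small. For compound 4 the estimate is 20000 nM with an expected range of 7000 nM to 60000 nM here.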

Compound 4, half-maximal effective concentration: 4600 nM
Beside the measured number, compound 4's estimate is 4.3-fold (0.64 log units) above it; the whole stated range lies above it.
By their numbers in this assay, from the lowest: compound 4; then compounds 3 and 2 (each within the scatter of the next). At a limit, above all of these: compound 1.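

In this assay, this position now separates groups that carry no charge: nitrile and hydroxymethyl had stayed within the scatter of each other, whereas ethoxy brings a 4.9-fold lower number from compound 3 to compound 4 (0.69 log units; beyond the scatter) and a 6.0-fold lower number from compound 2 to compound 4 (0.78 log units; beyond the scatter). Compound 1 gives a limit of the assay and not a number, so an at least 21-fold lower number from compound 1 to compound 4 (1.33 log units; beyond the scatter) is a bound as well: the limit of > 100000 nM in this assay, at which 1 of the 4 values shown sits.

Hydroxymethyl and ethoxy differ both in the hydrogen-bond donor and in heavy atoms, and the compounds shown do not tell which of these goes with the lower number. Going by these compounds, how a methoxy group, a longer alkoxy chain or an amine would read at this place stays open.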